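Halogen-to-hydrogen step on the shared core

The source may report more compounds than this note shows. Statements on the series, on what has been measured and on what is new or still open speak of the compounds shown alone.

Measured compounds:
compound 1 `Oc1ccccc1/C=N/Nc1ncc(F)cn1`, -13%
compound 2 `Oc1ccccc1/C=N/Nc1ncc(Cl)cn1`, 19%

Compound 2 stands highest of the two numbers in an assay on isolated protein for inhibition of lysine-specific demethylase 5A (Homo sapiens), read by AlphaLISA, with stated times of 15 min and 1 h, tested at 10 uM; a lower number here means less inhibition, a higher number more inhibition at the concentration tested (going by the name of the read-out); the nearest is compound 1, whose value lies lower by the step of a number 32 percentage points higher from compound 1 to compound 2 (beyond the scatter).

Compound 3 `Oc1ccccc1/C=N/Nc1ncccn1` is not yet measured in this assay. It differs from compound 2 by hydrogen in place of chloro on an aromatic carbon, the site being an aromatic carbon of a six-membered aromatic ring with two nitrogens, two atoms from the ring nitrogen.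

Going by the values given here, only one measured step bears on this: a number 32 percentage points higher from compound 1 to compound 2 (beyond the scatter), which shows that the halogen at this carbon matters and that the larger halogen gives the higher number. Going from chloro to hydrogen is a change at the same place, and the step from compound 1 to compound 2 is the only guide. The expectation is therefore a step downward in this assay, of a size comparable to the measured one, estimated as a number 24 percentage points lower from compound 2 to compound 3 (beyond the scatter).

Compound 3 is expected to give about -5% in this assay, within the estimated range -25% to 15%.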

Compound 3, a percentage reported as inhibition, at one concentration (the size of the read-out at that concentration, not a potency): 32%
For compound 3 the middle estimate is 37 percentage points below the measured one; the measured number lies above the stated range.
By their numbers in this assay, from the lowest: compound 1; then compound 2; then compound 3.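

Neither halogen at this aromatic carbon helps: in this assay, replacing chloro with hydrogen gives a number 13 percentage points higher from compound 2 to compound 3 (beyond the scatter), and replacing fluoro with hydrogen gives a number 45 percentage points higher from compound 1 to compound 3 (beyond the scatter), so the unsubstituted compound 3 stands highest of the three. The gain from fluoro to chloro is therefore a difference between two halogens and not a benefit of having a halogen here, and compound 3 goes against any reading in which a heavier atom at this carbon gives more inhibition. No measurement on hand accounts for this order.

The three compounds cover only hydrogen, fluoro and chloro at this one carbon, so they leave open whether a group of another kind, such as an amine, a methoxy group or a nitrile, would stand above or below compound 3. Each number also comes from a single concentration, so the order among the three says nothing yet about potency, and the other places on the shared core remain untested in this series as shown.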